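Uracil series: branched aliphatic amines at the chain carbon

A few compounds are considered here, and "the series" means these few. Any claim that something is new, unique, unknown or untested is made for them only; others in the source may bear on it.

Measured so far in an assay on HEK293 cells for binding affinity to Gonadotropin-releasing hormone receptor (Homo sapiens), read by radioligand binding; on this read-out lower numbers stand for stronger inhibition and higher numbers for weaker inhibition:
- compound 1 `COc1cccc(-c2c(C)n(Cc3c(F)cccc3F)c(=O)n(C[C@@H](N)CCc3ccccc3)c2=O)c1F` gives 965 nM
- compound 2 `COc1cccc(-c2c(C)n(Cc3c(F)cccc3F)c(=O)n(C[C@H](N)C(C)C)c2=O)c1F` gives 51 nM

Compound 1 stands highest of the two numbers; its nearest neighbour is compound 2, reached by a 19-fold lower number from compound 1 to compound 2 (1.28 log units; beyond the scatter), a large step beyond the scatter.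

Compound 3 `COc1cccc(-c2c(C)n(Cc3c(F)cccc3F)c(=O)n(C[C@H](N)C3CCCC3)c2=O)c1F` is not yet measured. It differs from compound 1 as follows: amino(cyclopentyl)methyl in place of 1-amino-3-phenylpropyl on a saturated chain carbon bound to an aromatic nitrogen.

Going by the values given here, the one measured step that bears on this change is the one from compound 1 to compound 2, where a branched aliphatic group replaced the same 1-amino-3-phenylpropyl and the number fell sharply. Amino(cyclopentyl)methyl is likewise a small branched aliphatic group, so a large step in the same direction is expected in this assay, of roughly the size seen for compound 2. The expected step is a 16-fold lower number from compound 1 to compound 3 (1.21 log units; beyond the scatter). For compound 3 the estimate is 60 nM, between 20 nM and 180 nM.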

Compound 3, inhibition constant: 10 nM
The estimate for compound 3 lay 6.0-fold (0.78 log units) above the measured number; measured number outside the range, below it.
By their numbers in this assay, from the lowest: compound 3; then compound 2; then compound 1.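

In this assay, going by these compounds alone, amino(cyclopentyl)methyl in place of 1-amino-3-phenylpropyl gives a 97-fold lower number from compound 1 to compound 3 (1.98 log units; beyond the scatter) and so is a second large step at this chain carbon, after the one to the isopropyl-bearing compound 2. The two aliphatic groups do not read alike: cyclopentyl in place of isopropyl gives a 5.1-fold lower number from compound 2 to compound 3 (0.71 log units; beyond the scatter) as a modest step beyond the scatter, so the group still shifts the number after the phenyl-bearing chain has gone. No supporting data explain why cyclopentyl and isopropyl differ here.

The step from compound 1 to compound 3 changes ring type and chain length together, so a phenyl or cyclohexyl group set directly on this carbon would be needed to separate the two. From the compounds shown here alone, whether a cyclobutyl or tert-butyl group, or a methyl group on the amine, would keep or lose this number remains open.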